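Taking the fluoro group off compound 3

The compounds below may be only part of what the source reports. "The series", "measured", "known", "first", "only" and "open" are said of these compounds alone.

Measured so far in a toxicity assay on HUVEC cells (Homo sapiens) for inhibition; on this read-out lower numbers stand for stronger inhibition of growth and higher numbers for weaker inhibition of growth:
compound 1 `Cc1cc(C)cc(N2CCN(C(=O)c3oc(C)nc3-c3ccccc3)CC2)c1` gives 0.356 ug/mL
compound 2 `Cc1nc(-c2ccccc2)c(C(=O)N2CCN(c3cc(Cl)cc(Cl)c3)CC2)o1` gives 0.191 ug/mL
compound 3 `Cc1nc(-c2ccccc2)c(C(=O)N2CCN(c3cccc(F)c3)CC2)o1` gives 1.05 ug/mL

Of these three, compound 3 has the highest number, 1.05 ug/mL in this assay, and so the weakest inhibition of growth. Compound 4 `Cc1nc(-c2ccccc2)c(C(=O)N2CCN(c3ccccc3)CC2)o1` differs from compound 3 by a single change (hydrogen in place of fluoro on an aromatic carbon) that puts hydrogen in place of fluoro on an aromatic carbon, turning 3-fluorophenyl into phenyl.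

Going by the values given here, no measured step makes this exact change, and no measured compound carries plain phenyl. The closest evidence comes from changes to the same group on the amine nitrogen. Two steps end at 3-fluorophenyl and both raise the number (a 2.9-fold higher number from compound 1 to compound 3 (0.47 log units; beyond the scatter)) and (a 5.5-fold higher number from compound 2 to compound 3 (0.74 log units; beyond the scatter)). The third step stays within the scatter (a 1.9-fold lower number from compound 1 to compound 2 (0.27 log units; within the scatter)). Both rises involve a larger change to that group than the loss of one fluoro, so a smaller move in the same upward direction is expected here. The expected step is a 1.4-fold higher number from compound 3 to compound 4 (0.15 log units; within the scatter) in this assay, and this direction remains uncertain. For compound 4 the estimated value is 1.5 ug/mL (expected range 0.6 ug/mL to 4 ug/mL).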

Compound 4, concentration for 50% growth inhibition: 9.63 ug/mL
Compound 4: the middle estimate sits 6.4-fold (0.81 log units) below what was measured; measured number above the stated range.
By their numbers in this assay, from the lowest: compounds 2 and 1 (each within the scatter of the next); then compound 3; then compound 4.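

In this assay, going by these compounds alone, the one fluoro on the aromatic carbon turns out to matter far more than the earlier compounds could show, with a 9.2-fold higher number from compound 3 to compound 4 (0.96 log units; beyond the scatter) for this single change. Plain phenyl gives the weakest inhibition of growth of the four compounds, with a 50-fold higher number from compound 2 to compound 4 (1.70 log units; beyond the scatter) and a 27-fold higher number from compound 1 to compound 4 (1.43 log units; beyond the scatter), so 3-fluorophenyl, 3,5-dichlorophenyl and 3,5-dimethylphenyl all give lower numbers than the unsubstituted ring, whether the added groups are halogens or methyl groups. Nothing available here explains why the phenyl compound stands so far from the other three.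

The compounds shown leave open whether a methoxy group or a nitrile in the same place would also give a lower number than hydrogen, or whether this holds only for the groups seen so far. They also leave open how a single chloro or a single methyl group would compare with the single fluoro, as 3,5-dichlorophenyl and 3,5-dimethylphenyl each carry two such groups.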